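Permeability notes: aryl ether to cyclohexylmethyl swap on the core

The source may report more compounds than this note shows. Statements on the series, on what has been measured and on what is new or still open speak of the compounds shown alone.

Compound 1 `COc1ccc(F)cc1CNCCCNc1ccnc2cc(Oc3cccc(N(C)C)c3)ccc12` and compound 2 `COc1cccc(CNCCCNc2ccnc3cc(Oc4cccc(N(C)C)c4)ccc23)c1O` share one core and differ only in the aryl group on the saturated chain carbon bound to the amine nitrogen. In an ADME assay for permeability, using PAMPA, with a stated time of 30 min, at pH 7.4 (on this read-out higher numbers stand for higher permeability and lower numbers for lower permeability), compound 1 gives 317 10^-6 cm/s and compound 2 gives 317 10^-6 cm/s; the step of no change at the digits printed from compound 1 to compound 2 (within the scatter). On this read-out compound 1 thus stands level with compound 2, and no other measured neighbour exists.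

Compound 3 `COc1ccc(F)cc1CNCCCNc1ccnc2cc(CC3CCCCC3)ccc12` keeps the left-hand part of compound 1 unchanged and alters the core: cyclohexylmethyl in place of 3-(dimethylamino)phenoxy on an aromatic carbon. Among the measured compounds shown here, no measured step touches this position. For the measured compounds named here, the only step measured, no change at the digits printed from compound 1 to compound 2 (within the scatter), concerns the other end of the molecule and so does not bear directly on the change in hand. With compound 1 at 317 10^-6 cm/s the reading is already high, and the working expectation is a step of a 1.1-fold lower number from compound 1 to compound 3 (0.02 log units; within the scatter), that is, none beyond the scatter. For compound 3 the estimated value in this assay is 300 10^-6 cm/s, with an expected range from 150 10^-6 cm/s to 550 10^-6 cm/s.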

Compound 3, apparent permeability: 23 10^-6 cm/s
Estimate against measurement, compound 3: 13-fold (1.12 log units) above, and the stated range ends above it.
By their numbers in this assay, from the lowest: compound 3; then compounds 1 and 2 (each within the scatter of the next).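

In this assay, this aromatic carbon is a position at which the read-out moves: cyclohexylmethyl in place of 3-(dimethylamino)phenoxy gives a 14-fold lower number from compound 1 to compound 3 (1.14 log units; beyond the scatter), a large step, whereas the aryl change at the other end of the molecule gave no change at the digits printed from compound 1 to compound 2 (within the scatter). The swap alters several things at once, as 10 heavy atoms with one nitrogen, one oxygen and 2 hydrogen-bond acceptors on an aromatic ring give way to 7 carbon atoms with no hydrogen-bond acceptors on a non-aromatic ring, so this single step cannot assign the drop to any one of these differences. No measurement at hand accounts for the size of the step.

Still open, on these data alone, is which part of the departing group matters: a plain phenoxy, a cyclohexyloxy or a benzyl group on the same aromatic carbon would separate the dimethylamino group, the ether oxygen and the aromatic ring from one another. Also open, as far as these compounds go, is whether cyclohexylmethyl gives a step of similar size when the 2-hydroxy-3-methoxyphenyl group of compound 2 stands at the other end of the molecule.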